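Pyrazole to Pyridine on a Shared Core

This account rests on a few compounds, and the source may have more. Where it says the series, first, only, none or still open, it means among the compounds named here.

Of the compounds shown here, two built on a shared core have been measured in a functional assay on MV4-11 cells (Homo sapiens) for antiproliferative activity, with a stated time of 6 days, tested at 1.56 uM; on this read-out lower numbers stand for a weaker effect and higher numbers for a stronger effect at the one concentration tested. Compound 1, `CNC(=O)N1CCCc2ccc(NC(=O)c3cccc(-c4ccn(C(C)=O)n4)c3)cc21`, gives 27.6% in this assay. Compound 2, `CNC(=O)N1CCCc2ccc(NC(=O)c3ccc(-c4ccn(C)n4)cc3)cc21`, gives 72.2% in this assay, the highest of the two numbers; its nearest neighbour is compound 1, which lies well below it, beyond the scatter. The two measured compounds differ from each other in more than one place, so no single step can be read between them, and the data offer no anchor for the change about to be made.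

Compound 3, `CNC(=O)N1CCCc2ccc(NC(=O)c3ccc(-c4ccccn4)cc3)cc21`, has not yet been measured. It differs from compound 2 in one place:
pyridin-2-yl in place of 1-methyl-1H-pyrazol-3-yl on an aromatic carbon
The group that enters is a six-membered aromatic ring with one hetero atom, one hydrogen-bond acceptor fewer than the group that leaves. Going by the values given here, with no comparable step among the measured compounds, the expected change is small, a slight fall that stays within the usual scatter: a number 10.2 percentage points lower from compound 2 to compound 3 (beyond the scatter). Compound 3 is therefore estimated at 62%, with a range from 35% to 85%.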

Compound 3, a percentage reported as inhibition, at one concentration (the size of the read-out at that concentration, not a potency): 32%
Estimate against measurement, compound 3: 30 percentage points above, outside the stated range (below it).
By their numbers in this assay, from the lowest: compounds 1 and 3 (each within the scatter of the next); then compound 2.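

The step shows that this position, para to a large group, is far from indifferent to which aromatic ring it carries: in this assay, pyridin-2-yl in place of 1-methyl-1H-pyrazol-3-yl gives a number 40.2 percentage points lower from compound 2 to compound 3 (beyond the scatter) even though the two groups have the same count of heavy atoms, no hydrogen-bond donors and no net charge. Matching the size of the group by heavy-atom count is therefore not enough to keep the read-out at this concentration, and the high value of compound 2 depends on the identity of its 1-methyl-1H-pyrazol-3-yl group. No measurement offered here explains why the number falls.

The swap changes ring size, hetero-atom count, acceptor count and the presence of the methyl group all at once, so this single step cannot assign the fall to any one of them. From the compounds shown here alone, a pyrazole without the methyl group, a 1-methylimidazole ring or a pyrimidine ring at this position would begin to separate those features, and how a plain phenyl ring would read out there remains open.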